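Aminothiophene piperazines: pyridyl swap for trifluoromethoxyphenyl

The compounds below may be only part of what the source reports. "The series", "measured", "known", "first", "only" and "open" are said of these compounds alone.

Of the compounds shown here, two sharing one core have been measured. Compound 1 `Nc1scc(CN2CCN(c3ccc(Cl)c(C(F)(F)F)c3)CC2)c1C(=O)c1ccc(Cl)cc1` gives -12% in a functional assay on CHO cells with adenosine receptor A1 (Homo sapiens) as the target, read by cAMP accumulation and immunoassay, with a stated time of 6 min, tested at 0.1 uM (a lower number here means a stronger effect, a higher number a weaker effect of the compound at the concentration tested), and compound 2 `Nc1scc(CN2CCN(c3ccc(OC(F)(F)F)cc3)CC2)c1C(=O)c1ccc(Cl)cc1` gives -13% in the same assay. The step of a number 1 percentage points lower from compound 1 to compound 2 (within the scatter) is within the scatter, so the two numbers are indistinguishable. Compound 2 stands with the lower of the two numbers, but its nearest neighbour is compound 1 and the gap between them is within the scatter. Compound 3 `Nc1scc(CN2CCN(c3ccncc3)CC2)c1C(=O)c1ccc(Cl)cc1` has not yet been measured. It differs from compound 2 by pyridin-4-yl in place of 4-(trifluoromethoxy)phenyl on an amine nitrogen in a ring. Within the data shown here, the one measured step at this position, that from compound 1 to compound 2, exchanged one aryl group for another and produced no change beyond the scatter. Among the measured compounds shown here, no measured step involves a pyridine at this position, so the expectation rests on that single uninformative step. Compound 3 is therefore expected to lie close to compound 2, with a step of about a number 3 percentage points higher from compound 2 to compound 3 (within the scatter), within the scatter. The estimate for compound 3 in this assay is -10%, with a range from -30% to 12%.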

Compound 3, a percentage reported as activity, at one concentration (the size of the read-out at that concentration, not a potency): 1.4%
Estimate against measurement, compound 3: 11.4 percentage points below; low and high end bracket the measured number.
By their numbers in this assay, from the lowest: compounds 2 and 1 (each within the scatter of the next); then compound 3.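

In this assay, this position does respond to the group on the ring nitrogen: pyridin-4-yl in place of 4-(trifluoromethoxy)phenyl gives a number 14.4 percentage points higher from compound 2 to compound 3 (beyond the scatter), and in place of 4-chloro-3-(trifluoromethyl)phenyl it gives a number 13.4 percentage points higher from compound 1 to compound 3 (beyond the scatter). The exchange between the two substituted phenyl groups had shown no such sensitivity, whereas this change, which brings a ring nitrogen and removes the substituents together, weakens the effect at the concentration tested. Nothing shown accounts for the size or direction of this step.

Since both features change at once, the compounds shown cannot tell which of them carries the step. On these data alone, an unsubstituted phenyl or a pyridin-3-yl group at this place would help to separate the two, and whether either would sit with compound 2 or with compound 3 remains open.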